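The compounds below may be only part of what the source reports. "The series", "measured", "known", "first", "only" and "open" are said of these compounds alone.

Compound 1 `COc1ccc(/C=C/C(=O)/C=C/c2ccc(OCc3cn(CCCCCOc4cc(=O)oc5ccccc45)nn3)c(OC)c2)cc1` gives 35%. Compound 2 `COc1ccc(/C=C/C(=O)/C=C/c2ccc(OCc3cn(CCCOc4cc(=O)oc5ccccc45)nn3)c(OC)c2)cc1OC` gives 67%. Compound 3 `COc1cc(/C=C/C(=O)/C=C/c2ccccc2)ccc1OCc1cn(CCCCCOc2cc(=O)oc3ccccc23)nn1` gives 24%.

All three were measured in a functional assay on HCT-116 cells (Homo sapiens) for inhibition, read by sulforhodamine B assay, with a stated time of 48 h, tested at 50 uM; on this read-out lower numbers stand for less inhibition of growth and higher numbers for more inhibition of growth at the one concentration tested. Compound 2 stands highest of the three, beyond the scatter against both others. Compound 3 differs from compound 1 by hydrogen in place of methoxy on an aromatic carbon, placed para to a large group; this step is a number 11 percentage points lower from compound 1 to compound 3 (beyond the scatter), a modest fall. How compound 1 and compound 2 differ is not broken down here.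

Compound 4 `COc1ccc(/C=C/C(=O)/C=C/c2ccc(OCc3cn(CCCOc4cc(=O)oc5ccccc45)nn3)c(OC)c2)cc1` has not been measured. It differs from compound 2 by hydrogen in place of methoxy on an aromatic carbon, placed ortho to a methoxy group and meta to a large group, so it is the same kind of change as from compound 1 to compound 3, though not at the same surroundings. Resting on a number 11 percentage points lower from compound 1 to compound 3 (beyond the scatter) from compound 1, a modest fall from compound 2 is expected, written as a number 17 percentage points lower from compound 2 to compound 4 (beyond the scatter). Compound 4 is therefore estimated at 50%, between 30% and 68%, with uncertainty because compound 1 gives 35% with only a longer chain separating it from compound 4.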

Compound 4, percent growth inhibition at one concentration: 54%
Compound 4: middle estimate off by 4 percentage points, on the low side, and the stated range covers the measured number.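

In this assay, swapping a methoxy for hydrogen gives a number 13 percentage points lower from compound 2 to compound 4 (beyond the scatter), and this step closely matches the one seen earlier on the other core: the same change on two cores in this assay, a number 11 percentage points lower (beyond the scatter) from compound 1 to compound 3 and a number 13 percentage points lower (beyond the scatter) from compound 2 to compound 4, 2 percentage points apart, within the scatter of two such steps Within these two pairs, then, removing one methoxy lowers growth inhibition by a similar modest amount on both cores, so the earlier step was a useful guide to the size of this one. Among the compounds shown here, this does not establish a general rule: there are only two pairs, the methoxy leaves different surroundings in each, and a single tested concentration cannot show why growth inhibition falls or whether the same step would appear at other concentrations.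

The compounds shown leave open whether a hydroxyl, a fluorine or an amine in that place would behave more like the methoxy or more like the hydrogen. For the compounds shown here, they also leave open whether the step would keep its size on a core carrying a chain longer than the one in compound 1.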